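The source may hold more compounds than are shown below. What is called first, only, known or untested is meant among the compounds shown, and "the series" means these compounds.

Compound 1 `CCc1cc2cc(OC)cc(C(=O)c3ccc(OC)cc3)c2o1` carries a methoxy group on the benzoyl ring and a second methoxy on the shared core. In an assay for inhibition of solute carrier family 22 member 12 (Homo sapiens), read by scintillation counting, with a stated time of 60 min (a lower number here means a stronger inhibitor, a higher number a weaker inhibitor), compound 1 is recorded as "not determined" (no result reported), so it stands without a number. Among the compounds with values here, compound 2 `CCc1cc2c(C(=O)c3ccc(O)cc3)c(OC)ccc2o1`, which pairs a hydroxy on the benzoyl ring with a methoxy on its core, is the only member of the set with a figure: in this assay compound 2 gives 6680 nM. Compound 3 `CCc1cc2c(C(=O)c3ccc(OC)cc3)c(O)ccc2o1`, the arrangement with the methoxy on the benzoyl ring and the hydroxy on the core, likewise stands without a number: in this assay compound 3 is recorded as "not determined" (no result reported).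

Compound 4 `CCc1cc2cc(OC)cc(C(=O)c3ccc(O)cc3)c2o1` arises from compound 1 by hydrogen in place of methyl on an oxygen on an aromatic ring. Within the data shown here, no comparison between measured compounds covers this change, so no size or direction of step can be drawn from the set; compound 4 keeps the ethyl-bearing core of compound 1 and takes on the phenol of compound 2.

Compound 4 is therefore expected to come in near 6000 nM, within a range of 1500 nM to 25000 nM, an estimate that leans on compound 2 because compound 2 gives 6680 nM in this assay.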

Compound 4, half-maximal inhibitory concentration: 33700 nM
Compound 4: middle estimate off by 5.6-fold (0.75 log units), on the low side; measured number above the stated range.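

Compound 4 now has a number while compound 1 has none, so no new step can be read between them. The compounds shown leave open how far methoxy to hydroxy on this oxygen shifts inhibition. No other data bear on the result.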